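Methyl on Two Different Rings in a Cytotoxicity Series

The compounds below may be only part of what the source reports. "The series", "measured", "known", "first", "only" and "open" are said of these compounds alone.

Compound 1 `Cn1c(-c2ccc(NC(=O)CSc3nc4ccccc4o3)cc2)nc(-c2ccccc2)c1-c1ccccc1` gives 27.4% in a functional assay on MCF7 cells (Homo sapiens) for cytotoxicity, read by MTT assay, with a stated time of 24 h, tested at 1.6 ug/mL; on this read-out higher numbers stand for a stronger effect at the one concentration tested and lower numbers for a weaker effect. Compound 2 `Cc1ccc2oc(SCC(=O)Nc3ccc(-c4nc(-c5ccccc5)c(-c5ccccc5)n4C)cc3)nc2c1` gives 1.9% in this assay; here methyl in place of hydrogen on an aromatic carbon made a number 25.5 percentage points lower from compound 1 to compound 2 (beyond the scatter). Compound 3 `Cn1c(-c2ccc(NC(=O)CN3CCN(Cc4ccccc4)CC3)cc2)nc(-c2ccccc2)c1-c1ccccc1` gives 13.3% in this assay; how its core differs from that of compound 1 is not broken down here. Compound 4 `Cc1ccc(CN2CCN(CC(=O)Nc3ccc(-c4nc(-c5ccccc5)c(-c5ccccc5)n4C)cc3)CC2)cc1` differs from compound 3 by methyl in place of hydrogen on an aromatic carbon. This is the same kind of change as before, not the same: in compound 2 the methyl sits on a ring that is part of a fused or bridged system of two rings, meta and para to a fused ring, whereas in compound 4 it sits on a six-membered ring of carbon only, para to a large group. Compound 4 is expected to show a number 7.3 percentage points lower from compound 3 to compound 4 (within the scatter), a smaller drop than the earlier one because compound 3 already gives 13.3%. Compound 4 is estimated at 6%, between 0% and 22%.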

Compound 4, a percentage reported as activity, at one concentration (the size of the read-out at that concentration, not a potency): 19.3%
Compound 4: the middle estimate sits 13.3 percentage points below what was measured; low and high end bracket the measured number.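

In this assay, methyl in place of hydrogen on an aromatic carbon gives a number 6 percentage points higher from compound 3 to compound 4 (within the scatter). Set beside the earlier step, the same change does not carry over between these two cores: the same change on two cores in this assay, a number 25.5 percentage points lower (beyond the scatter) from compound 1 to compound 2 and a number 6 percentage points higher (within the scatter) from compound 3 to compound 4, 31.5 percentage points apart, beyond the scatter of two such steps. For the compounds shown here, this shows that the outcome of the methyl on one core cannot be read across to the other, but it does not show why, as the methyl sits on a different ring in each pair and each core offers only one pair.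

The compounds shown leave open how a methoxy group or a chlorine atom in place of that methyl would behave on either core. They also leave open whether a second pair on each core would repeat these steps.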